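Swapping Methyl for Trifluoromethyl on the Shared Core

The source may hold more compounds than are shown below. What is called first, only, known or untested is meant among the compounds shown, and "the series" means these compounds.

Measured in a functional assay on SK-OV-3 cells (Homo sapiens) for cytotoxicity, read by MTT assay, with a stated time of 48 h (a higher number here means a weaker inhibitor, a lower number a stronger inhibitor), so far:
compound 1 `O=C(/C=C/c1ccc2c(c1)B(O)OC2)c1ccc(Cl)cc1` gives 3700 nM
compound 2 `O=C(/C=C/c1ccc2c(c1)B(O)OC2)c1ccc(I)cc1` gives 4200 nM
compound 3 `Cc1ccc(C(=O)/C=C/c2ccc3c(c2)B(O)OC3)cc1` gives 3700 nM

Compound 3 stands level with compound 1, and these two share the lowest number of the three; compound 2 lies furthest away, as a 1.1-fold lower number from compound 2 to compound 3 (0.06 log units; within the scatter) shows. Compound 4 `O=C(/C=C/c1ccc2c(c1)B(O)OC2)c1ccc(C(F)(F)F)cc1` differs from compound 3 by one change: trifluoromethyl in place of methyl on an aromatic carbon. Within the data shown here, the steps that bear on it are a 1.1-fold higher number from compound 1 to compound 2 (0.06 log units; within the scatter), no change at the digits printed from compound 1 to compound 3 (within the scatter) and a 1.1-fold lower number from compound 2 to compound 3 (0.06 log units; within the scatter), all within the scatter, so exchanging groups at this place has so far moved nothing. Among the measured compounds shown here, no measured compound carries trifluoromethyl, so the step is expected to stay within the scatter: a 1.1-fold higher number from compound 3 to compound 4 (0.02 log units; within the scatter). Compound 4 is therefore estimated at 3900 nM, with a range from 1800 nM to 8500 nM.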

Compound 4, half-maximal inhibitory concentration: 3700 nM
The estimate for compound 4 lay 1.1-fold (0.02 log units) above the measured number; the range from low to high includes it.
By their numbers in this assay, from the lowest: compounds 1, 3, 4 and 2 (each within the scatter of the next).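

Trifluoromethyl brings four heavy atoms where methyl has one, yet in this assay the number holds (no change at the digits printed from compound 3 to compound 4 (within the scatter)), and it also holds against chloro (no change at the digits printed from compound 1 to compound 4 (within the scatter)) and iodo (a 1.1-fold lower number from compound 2 to compound 4 (0.06 log units; within the scatter)). All four groups on this aromatic carbon therefore read alike, so even this larger group leaves the result where it was. Nothing measured here offers a reason for this sameness.

From the compounds shown here alone, whether an amine, a carboxylic acid or a longer chain at this place would also leave the number unmoved stays open, as does the effect of changes elsewhere on the shared core.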